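Amide nitrogen substitution on a benzothiophene-dioxide core

The source may report more compounds than this note shows. Statements on the series, on what has been measured and on what is new or still open speak of the compounds shown alone.

Measured compounds:
compound 1 `NC(=O)c1ccc2c(c1)S(=O)(=O)C=C2`: 650 nM
compound 2 `COc1ccc(NC(=O)c2ccc3c(c2)S(=O)(=O)C=C3)cc1`: 3 nM

Going by the values given here, in a functional assay on HeLa cells (Homo sapiens) for cytotoxicity, read by MTT assay, with a stated time of 72 h (a lower number here means a stronger inhibitor of growth, a higher number a weaker inhibitor of growth), compound 1 gives 650 nM, the higher of the two numbers measured so far. Compound 2 carries a 4-methoxyphenyl group on the amide nitrogen and gives 3 nM in this assay, a number far below that of compound 1 and well beyond the scatter.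

Compound 3 `CCCCNC(=O)c1ccc2c(c1)S(=O)(=O)C=C2` is the butyl amide of the same core. Relative to compound 1 the change is butyl in place of hydrogen on an amide-type nitrogen. Among the compounds with values here, no directly comparable step has been measured, so the expectation rests on the two values above: filling the amide nitrogen, as in compound 2 with its 3 nM, is associated with a much lower number, though butyl is a chain rather than a ring and the effect may be smaller. For compound 3 the step of a 5.4-fold lower number from compound 1 to compound 3 (0.73 log units; beyond the scatter) is expected, giving an estimate of 120 nM with a range from 20 nM to 700 nM.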

Compound 3, concentration for 50% growth inhibition: 80 nM
The estimate for compound 3 lay 1.5-fold (0.18 log units) above the measured number, and the stated range covers the measured number.
By their numbers in this assay, from the lowest: compound 2; then compound 3; then compound 1.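

In this assay, the change from hydrogen to butyl gives an 8.1-fold lower number from compound 1 to compound 3 (0.91 log units; beyond the scatter), so a plain chain without a ring on the amide-type nitrogen is enough to lower the number beyond the scatter. The lower number at this position is therefore not confined to the 4-methoxyphenyl group, although on the printed values compound 3 at 80 nM still stands above compound 2 at 3 nM. Nothing at hand accounts for either lowering.

A single chain leaves the dependence on length open, and a methyl group or an octyl chain on the same nitrogen would test it. An unsubstituted phenyl ring or a benzyl group would help separate the contribution of the ring from that of the methoxy group in compound 2.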